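Swapping a trichlorophenyl ether for a bromophenyl ether

The source may report more compounds than this note shows. Statements on the series, on what has been measured and on what is new or still open speak of the compounds shown alone.

In an assay on isolated protein for inhibition of Dihydrofolate reductase (Homo sapiens), read by spectrophotometry, using NADPH, with stated times of 5 s and 6 min, tested at 5 uM (a lower number here means a weaker effect, a higher number a stronger effect of the compound at the concentration tested), the three measured compounds gave:
compound 1 `NC1=NC2(CCSCC2)N(OCCCOc2cccc(Cl)c2)C(N)=N1`: 88.3%
compound 2 `NC1=NC2(CCOCC2)N(OCCCOc2cc(Cl)c(Cl)cc2Cl)C(N)=N1`: > 90%, a limit of the assay rather than a number
compound 3 `NC1=NC2(CCSCC2)N(OCCCOc2ccc(Br)cc2)C(N)=N1`: > 90%, also a limit of the assay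

Compound 2 thus stands at the limit of > 90% in this assay, at which 2 of the 3 values shown sit. Among the measured compounds shown here, the only step measured between neighbours, a number at least 1.7 percentage points higher from compound 1 to compound 3 (that floor lies within the scatter), exchanges one halogenated phenyl for another and stays within the scatter. Compound 4 `NC1=NC2(CCOCC2)N(OCCCOc2cccc(Br)c2)C(N)=N1` differs from compound 2 by 3-bromophenyl in place of 2,4,5-trichlorophenyl on an oxygen on a saturated carbon. For the measured compounds named here, no measured step makes this exact change, so the expectation rests on the halogen swap just described, which left the read-out essentially unchanged. Compound 4 is therefore expected to remain high, with an estimated step of a number at least 2 percentage points lower from compound 2 to compound 4 (that floor lies within the scatter) that is small or none beyond the scatter. The estimate for compound 4 is 88%, expected to fall between 78% and 95%.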

Compound 4, a percentage reported as inhibition, at one concentration (the size of the read-out at that concentration, not a potency): 86.7%
Compound 4: middle estimate off by 1.3 percentage points, on the high side, and the stated range covers the measured number.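

The step from 2,4,5-trichlorophenyl to 3-bromophenyl on this oxygen is a number at least 3.3 percentage points lower from compound 2 to compound 4 (that floor lies within the scatter). The earlier step exchanged one halogenated phenyl for another on the core of compound 1, whereas this one shows that a phenyl with a single bromine, and fewer heavy atoms, is also tolerated on the core of compound 2. Compound 2 itself sits at a limit, not a number: the limit of > 90% in this assay, at which 2 of the 4 values shown sit.

All the phenyl groups shown carry halogens. On these data alone, whether an amine or a carboxylic acid on that ring, or a longer chain before it, would keep the read-out this high stays open.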